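Quinoline carboxamides: hydroxy to carboxy on the core

A few compounds are considered here, and "the series" means these few. Any claim that something is new, unique, unknown or untested is made for them only; others in the source may bear on it.

Series notes. Compound 1 `CCOc1ccc2nc(C(=O)Nc3c(F)cc(-c4cccc(F)c4)cc3F)c(C)c(O)c2c1` carries a hydroxy group on the core and two fluorine atoms on the anilide ring together with a fluorophenyl group. Compound 3 `CCOc1ccc2nc(C(=O)Nc3c(F)cc(-c4cccc(F)c4)cc3F)c(C)c(C(=O)O)c2c1` differs from it in one place: carboxy in place of hydroxy on an aromatic carbon. Compound 2 `COc1ccc2nc(C(=O)Nc3ccc(-c4ccccc4)cc3)c(C)c(O)c2c1` has a methoxy group on the core and an unfluorinated biphenyl anilide; the difference between the core of compound 2 and the core of compound 1 is not broken down here. Compound 4 `COc1ccc2nc(C(=O)Nc3ccc(-c4ccccc4)cc3)c(C)c(C(=O)O)c2c1` is the counterpart of compound 2 with the same single change, (carboxy in place of hydroxy on an aromatic carbon), and is not yet measured.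

In a functional assay on A-375 cells (Homo sapiens) for antiproliferative activity, read by MTT assay, with a stated time of 24 h, tested at 3.7 ug/mL (a lower number here means a weaker effect, a higher number a stronger effect of the compound at the concentration tested), compound 1 gives 4.56%. In this assay compound 3 gives 35.2%; the change a number 30.6 percentage points higher from compound 1 to compound 3 (beyond the scatter). In this assay compound 2 gives 27.2%, which lies within the scatter of compound 3 and beyond it relative to compound 1.

The change from compound 2 to compound 4 is the same change that was made from compound 1 to compound 3; the two place descriptions agree word for word. Going by the values given here, with only one measured example of this step, and that on a differently substituted anilide, the carry-over is uncertain. A step of roughly the same size is nonetheless the working expectation, a number 24.8 percentage points higher from compound 2 to compound 4 (beyond the scatter), because a number 30.6 percentage points higher from compound 1 to compound 3 (beyond the scatter). In this assay compound 4 is therefore expected to give about 52%. The estimated range for compound 4 runs from 30% to 74%.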

Compound 4, a percentage reported as inhibition, at one concentration (the size of the read-out at that concentration, not a potency): 33.7%
The estimate for compound 4 lay 18.3 percentage points above the measured number, within the range that was stated.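

In this assay, the change from hydroxy to carboxy does not carry over in size from one core to the other: the same change on two cores in this assay, a number 30.6 percentage points higher (beyond the scatter) from compound 1 to compound 3 and a number 6.5 percentage points higher (within the scatter) from compound 2 to compound 4, 24.1 percentage points apart, beyond the scatter of two such steps. On the core of compound 2 the same change gives a number 6.5 percentage points higher from compound 2 to compound 4 (within the scatter), so a gain of the size seen with compound 3 cannot be assumed when this change is moved to another core in the series. This does not show which structural difference sets the gap, as the two pairs differ at once in the alkoxy group on the core, in the fluorine atoms on the anilide ring and in the fluorine on the terminal phenyl group, and two pairs cannot separate these features.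

Still open, from the compounds shown here alone, is whether the size of the step follows the alkoxy group, the fluorine atoms on the anilide ring or the fluorine on the terminal phenyl group, a question that only pairs differing in one of these features could settle. Also open, going by these compounds, is how an amine or a primary amide would read in this assay on either core, in the place held here by hydroxy and carboxy.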